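The compounds below may be only part of what the source reports. "The series", "measured", "known", "first", "only" and "open" are said of these compounds alone.

Compound 1 `COc1cc(-c2ccnc3cc(-c4ccc(Cl)cc4)nn23)cc(OC)c1OC` is the starting point of this account. In a functional assay on MCF7 cells (Homo sapiens) for inhibition, read by CCK-8 assay, with a stated time of 48 h (on this read-out lower numbers stand for stronger inhibition and higher numbers for weaker inhibition), compound 1 gives 2320 nM, the lowest of the two numbers that were read out as numbers. Compound 2 `Cn1ccc2cc(-c3cc4nccc(-c5ccc(F)cc5)n4n3)ccc21` gives 4580 nM in this assay, and the two values lie within the usual scatter of each other, so no order between them can be claimed. Compound 3 `COc1ccc(-c2cc3nccc(-c4cc(OC)c(OC)c(OC)c4)n3n2)cc1[N+](=O)[O-]` is reported in this assay only as a limit, > 10000 nM, as noted by the limit of > 10000 nM in this assay, at which 1 of the 3 values shown sits.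

The step followed here leads from compound 1 to compound 4 `COc1cc(-c2ccnc3cc(-c4ccc(C(C)(C)C)cc4)nn23)cc(OC)c1OC`. The change is tert-butyl in place of chloro on an aromatic carbon, para to a large group. Among the compounds with values here, no measured pair with this kind of change is available, so nothing among the measured compounds points to a direction. The expected step of a 1.3-fold higher number from compound 1 to compound 4 (0.11 log units; within the scatter) is therefore small, not beyond the scatter. Compound 4 is expected to give 3000 nM, with a range from 1000 nM to 9000 nM.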

Compound 4, half-maximal inhibitory concentration: > 10000 nM
Compound 4 ended at the assay's limit (the forecaster's own chance of this, stated with the estimate: 15%); middle value at least 3.3-fold (0.52 log units) away from the limit.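

Within the data shown here, this is the first change in a single place that can be read in this assay, and it shows that the group at this position matters: tert-butyl in place of chloro gives an at least 4.3-fold higher number from compound 1 to compound 4 (0.63 log units; beyond the scatter). Of the two groups tried here, chloro is therefore the one that keeps a measurable number, and a bulkier-looking substituent count of carbon alone does not carry that number over. Compound 4 is reported only as a limit, so the true size of the step stays unknown, and compound 4 now sits with compound 3 at the same limit: the limit of > 10000 nM in this assay, at which 2 of the 4 values shown sit.

A methyl, a methoxy or an amine in the same place would show whether the loss belongs to tert-butyl alone or appears with any group other than chloro. From the compounds shown here alone, whether any group here could give a lower number than compound 1 also stays open.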